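Iodo in Place of Bromo: Expecting Little Change

This account rests on a few compounds, and the source may have more. Where it says the series, first, only, none or still open, it means among the compounds named here.

Of the compounds shown here, three sharing one core have been measured in a functional assay on L1210 cells (Mus musculus) for antiproliferative activity, with a stated time of 48 h; a lower number here means a stronger inhibitor, a higher number a weaker inhibitor. Compound 1 `Nc1ccc(/C=C/C(=O)c2ccccc2)cc1` gives 88000 nM, compound 2 `Nc1ccc(/C=C/C(=O)c2ccc(F)cc2)cc1` gives 123000 nM, and compound 3 `Nc1ccc(/C=C/C(=O)c2ccc(Br)cc2)cc1` gives 90000 nM. Compound 3 therefore cannot be separated from the other two, as its gaps to both lie within the usual scatter of repeated measurements.

Compound 4 `Nc1ccc(/C=C/C(=O)c2ccc(I)cc2)cc1` differs from compound 3 by a single change: iodo in place of bromo on an aromatic carbon, para to a large group. For the measured compounds named here, no iodo compound has been measured yet, so the best guide is the earlier changes at this same place. Fluoro in place of hydrogen gave a 1.4-fold higher number from compound 1 to compound 2 (0.15 log units; within the scatter), bromo in place of hydrogen gave a 1.0-fold higher number from compound 1 to compound 3 (0.01 log units; within the scatter), and bromo in place of fluoro gave a 1.4-fold lower number from compound 2 to compound 3 (0.14 log units; within the scatter). None of these steps leaves the scatter, so no step beyond the scatter, in either direction, is expected in this assay.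

The estimated step is a 1.1-fold lower number from compound 3 to compound 4 (0.02 log units; within the scatter). The estimate for compound 4 is 85000 nM, with an expected range from 45000 nM to 150000 nM.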

Compound 4, half-maximal inhibitory concentration: 50000 nM
For compound 4 the middle estimate is 1.7-fold (0.23 log units) above the measured one, within the range that was stated.
By their numbers in this assay, from the lowest: compounds 4, 1, 3 and 2 (each within the scatter of the next, the first and the last beyond it).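

In this assay, for the compounds shown here, iodo against fluoro is the only pair of groups at this position whose gap lies beyond the scatter, though modestly: a 2.5-fold lower number from compound 2 to compound 4 (0.39 log units; beyond the scatter). Against bromo and against hydrogen, iodo stays within the scatter, with a 1.8-fold lower number from compound 3 to compound 4 (0.26 log units; within the scatter) and a 1.8-fold lower number from compound 1 to compound 4 (0.25 log units; within the scatter), so the position still shows no clear gain over the compound carrying plain hydrogen. Nothing available here explains why iodo and fluoro come apart.

Going by these compounds alone, every group at this position so far is hydrogen or a halogen, so it remains open whether a different kind of group, such as an amine, a methoxy group or a carboxylic acid, would move the number further. On these data alone, it also remains open whether the modest gap between the iodo and fluoro compounds would hold in other cell lines.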